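A few compounds are considered here, and "the series" means these few. Any claim that something is new, unique, unknown or untested is made for them only; others in the source may bear on it.

In a functional assay on MCF7 cells (Homo sapiens) for antiproliferative activity, read by sulforhodamine B assay, with a stated time of 72 h (a higher number here means a weaker inhibitor, a lower number a stronger inhibitor), compound 2 `FC(F)(F)c1cccc(/C=C\c2cc3ccccc3nc2Cl)c1` gives 3530 nM and compound 1 `FC(F)(F)c1ccc(/C=C\c2cc3ccc(Cl)cc3nc2Cl)cc1` gives 6450 nM, two values within the scatter of each other. Compound 3 `FC(F)(F)c1cccc(/C=C/c2cc3ccccc3nc2Cl)c1` stands apart at 24400 nM. That gap, a 6.9-fold higher number from compound 2 to compound 3 (0.84 log units; beyond the scatter), goes with the fact that compounds 2 and 3 differ only in the configuration as drawn.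

Compound 4 `COc1ccc2nc(Cl)c(/C=C\c3cccc(C(F)(F)F)c3)cc2c1` keeps the Z double bond of compound 2 and changes the core: methoxy in place of hydrogen on an aromatic carbon. Within the data shown here, no measured step isolates this change. Among the measured compounds shown here, the one step available concerns configuration, not a substituent, so its size does not carry over. The nearest hint is compound 1, which carries an added chloro group on the core and still gives 6450 nM, within the scatter of compound 2, although it also differs in a second place. From the compounds shown here alone, no step beyond the scatter is therefore expected in this assay, and the direction remains open. The expected result is a 1.1-fold higher number from compound 2 to compound 4 (0.05 log units; within the scatter). For compound 4 the estimated value is 4000 nM, with an expected range from 1500 nM to 11000 nM.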

Compound 4, half-maximal inhibitory concentration: 2780 nM
Compound 4: the middle estimate sits 1.4-fold (0.16 log units) above what was measured, within the range that was stated.
By their numbers in this assay, from the lowest: compounds 4, 2 and 1 (each within the scatter of the next, the first and the last beyond it); then compound 3.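

In this assay, among these compounds, a 1.3-fold lower number from compound 2 to compound 4 (0.10 log units; within the scatter) is the first step that isolates a substituent on the core, and it stays within the scatter. With the Z double bond kept, methoxy in place of hydrogen on this aromatic carbon, on the six-membered aromatic ring of carbon only, gives a number that cannot be told apart from that of compound 2, so this position accepts the added group without a step beyond the scatter. Nothing given here speaks to what lies behind this result.

From the compounds shown here alone, whether an amine, a carboxylic acid or a longer alkoxy chain at this carbon would stay equally close to compound 2 remains open. Also open, going by these compounds, is whether methoxy would give the same result on the E double bond of compound 3.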